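The source may report more compounds than this note shows. Statements on the series, on what has been measured and on what is new or still open speak of the compounds shown alone.

In an ADME assay on the whole organism (strain 129/SvEvBrd x C57BL/6) for metabolic stability, with Mus musculus as the target (on this read-out lower numbers stand for a shorter-lived compound and higher numbers for a longer-lived compound), compound 1 `CC(=O)c1ncc([C@@H](O)[C@H](O)[C@H](O)CO)s1` gives 0.9 h, while compound 2 `CC(O)c1nc([C@@H](O)[C@H](O)[C@H](O)CO)c[nH]1` gives 4.4 h. Compound 2 therefore holds the higher of the two numbers, and the gap between them is larger than the usual scatter of repeat measurements.

The next structure is compound 3 `OC[C@@H](O)[C@@H](O)[C@H](O)c1c[nH]c(-c2cscn2)n1`, which has not yet been measured. It differs from compound 2 in one place: 1,3-thiazol-4-yl in place of 1-hydroxyethyl on an aromatic carbon. Put simply, 1,3-thiazol-4-yl stands in place of 1-hydroxyethyl on an aromatic carbon, between two ring nitrogen atoms.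

Among the compounds with values here, no two measured compounds differ in just one place, so the data do not directly show what a swap like this does. Within the data shown here, compound 1 at 0.9 h is the only reference besides compound 2 at 4.4 h, so the expectation is loose: a small move towards the lower number in this assay, staying within the scatter. The estimated change is a 1.8-fold lower number from compound 2 to compound 3 (0.25 log units; within the scatter). For compound 3 the expected half-life is 2.5 h, with an estimated range of 0.9 h to 6 h.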

Compound 3, half-life: 4.2 h
Estimate against measurement, compound 3: 1.7-fold (0.23 log units) below, and the stated range covers the measured number.
By their numbers in this assay, from the lowest: compound 1; then compounds 3 and 2 (each within the scatter of the next).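

In this assay, putting 1,3-thiazol-4-yl in place of 1-hydroxyethyl on this aromatic carbon, between two ring nitrogen atoms, gives a 1.0-fold lower number from compound 2 to compound 3 (0.02 log units; within the scatter), so the read-out does not tell the two compounds apart. Within the data shown here, this is the first direct comparison at this position, and it shows that a short open chain can give way to a five-membered aromatic ring, with the hydrogen-bond donor of 1-hydroxyethyl gone, and the half-life stays within the usual scatter. Nothing available here explains why these two different groups give matching half-lives in the mouse.

The compounds shown leave open how an amine, a carboxylic acid or a longer chain at this position would fare on this read-out. They also leave open whether the match between 1-hydroxyethyl and 1,3-thiazol-4-yl would hold on another core, and compound 1 cannot settle this, as it differs from compound 2 and compound 3 in more than one place.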